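A Methyl-to-Methoxy Swap on a Prostaglandin Receptor Ligand

The source may report more compounds than this note shows. Statements on the series, on what has been measured and on what is new or still open speak of the compounds shown alone.

Compound 1 `O=C(O)/C=C/c1ccc(Cn2cccn2)cc1OCCc1ccc2ccccc2c1`: 3300 nM
Compound 2 `Cc1ccc(/C=C/C(=O)O)c(OCCC2(C)CCc3c(C)c(O)c(C)c(C)c3O2)c1`: 5700 nM

Of the compounds shown here, two have been measured in an assay on CHO cells for displacement of a labelled ligand from prostaglandin E2 receptor EP2 subtype (Mus musculus), read by scintillation counting; a higher number here means a weaker inhibitor, a lower number a stronger inhibitor. Compound 2 gives 5700 nM, while compound 1 gives 3300 nM; the gap between these two numbers lies within the scatter, so neither compound can be set apart from the other. Compound 3 `COc1ccc(/C=C/C(=O)O)c(OCCC2(C)CCc3c(C)c(O)c(C)c(C)c3O2)c1` has not yet been measured. It differs from compound 2 in one place: methoxy in place of methyl on an aromatic carbon, on an aromatic carbon of a six-membered aromatic ring of carbon only, meta to a large group and para to a 2-carboxyethenyl group. For the measured compounds named here, no comparable step between measured compounds exists, so nothing measured tells how this swap shifts binding. Because compound 2 gives 5700 nM, the step of a 1.1-fold lower number from compound 2 to compound 3 (0.06 log units; within the scatter) is expected to stay within the scatter. Compound 3 is estimated at 5000 nM, between 1700 nM and 15000 nM.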

Compound 3, inhibition constant: 6800 nM
Estimate against measurement, compound 3: 1.4-fold (0.13 log units) below; low and high end bracket the measured number.
By their numbers in this assay, from the lowest: compounds 1, 2 and 3 (each within the scatter of the next, the first and the last beyond it).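

In this assay, the swap to methoxy in place of methyl on this aromatic carbon, meta to a large group and para to a 2-carboxyethenyl group, gives a 1.2-fold higher number from compound 2 to compound 3 (0.08 log units; within the scatter) as the first step measured between two compounds that differ in one place. The position therefore takes the oxygen of a methoxy group, with its hydrogen-bond acceptor, without a shift in binding that can be told apart from the scatter of repeated measurements. No measured evidence bears on why this is so.

On these data alone, whether a group of another kind on this same carbon, such as an amine, a hydroxyl or a chlorine atom, would move the number beyond the scatter remains open. As far as these compounds go, it is also open whether methoxy in place of methyl would read the same on a different core.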